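What fixing one stereocentre may do to compound 2

The source may hold more compounds than are shown below. What is called first, only, known or untested is meant among the compounds shown, and "the series" means these compounds.

Compound 1 `CCCCC(CCO)n1cnc2c(Cl)ncnc21`: > 50000 nM (a limit, not a number)
Compound 2 `CCCCCCCC(CCO)n1cnc2c(Cl)ncnc21`: 3630 nM

Both results come from a functional assay on SW480 cells (Homo sapiens) for antiproliferative activity, read by MTT assay, with a stated time of 48 h; on this read-out higher numbers stand for weaker inhibition and lower numbers for stronger inhibition. Compound 1 reaches only a limit, > 50000 nM. Going by the values given here, compound 2 therefore holds the only true number so far, 3630 nM.

The next compound, compound 3 `CCCCCCC[C@@H](CCO)n1cnc2c(Cl)ncnc21`, has the same atoms and bonds as compound 2: the two compounds have the same atoms and bonds; at least one stereo element is drawn with a configuration in one of them and without one in the other: 1 of 1 stereo elements differ; a stereocentre at a saturated chain carbon is drawn without a configuration in compound 2 and S in compound 3. The stereocentre at a saturated chain carbon is drawn without a configuration in compound 2 and S in compound 3.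

Among the compounds with values here, the only measured step, an at least 13-fold lower number from compound 1 to compound 2 (1.13 log units; beyond the scatter), is large. Within the data shown here, it comes from propyl in place of hydrogen on a saturated chain carbon, however, and no measured step shows what a change of configuration does. Its size therefore cannot be carried over, and the estimate rests mainly on compound 2 at 3630 nM.

In this assay, no clear change beyond the scatter is expected, with at most a slight lean towards a lower number. The expected step is a 1.2-fold lower number from compound 2 to compound 3 (0.08 log units; within the scatter). The estimated value for compound 3 is 3000 nM, with an expected range from 1400 nM to 6500 nM.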

Compound 3, half-maximal inhibitory concentration: 3820 nM
The estimate for compound 3 lay 1.3-fold (0.10 log units) below the measured number; the range from low to high includes it.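

In this assay, the measured change of configuration is a 1.1-fold higher number from compound 2 to compound 3 (0.02 log units; within the scatter), so drawing the stereocentre at this saturated chain carbon as S leaves the result within the usual scatter of compound 2. The earlier pair showed only what a longer chain does, and that comparison had a limit rather than a true number at one end: the limit of > 50000 nM in this assay, at which 1 of the 3 values shown sits. Compounds 2 and 3 both give true numbers, so this pair allows a direct comparison, but it must be read with care, since the drawing of compound 2 does not say which spatial form or mixture of forms the sample contains: the fact that one of compounds 2 and 3 is drawn with a defined configuration and the other without, at the place where they differ.

The compounds shown leave open how a compound drawn R at this same carbon would read, and that comparison would show whether the configuration here matters at all in this cell assay. They also leave open whether the S compound would keep its reading with a longer chain, or with an amine or a carboxylic acid in place of the hydroxyl.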